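Chloromethylbenzyl purines: removing a ring chloro

The source may report more compounds than this note shows. Statements on the series, on what has been measured and on what is new or still open speak of the compounds shown alone.

Two compounds of this series have been run in a functional assay on TK-10 cells (Homo sapiens) for cytotoxicity, read by sulforhodamine B assay, with a stated time of 48 h (a higher number here means that more compound is tolerated, a lower number that less compound is tolerated), so far. Compound 1 `Nc1nc(Cl)c2ncn(Cc3ccc(CCl)cc3)c2n1` carries an amino group on its core and gives 97700 nM in this assay. Compound 2 `ClCc1ccccc1Cn1cnc2nc(Cl)nc(Cl)c21` is the dichlorinated analogue with the chloromethyl group moved to the other position of the benzyl ring; in this assay compound 2 gives 60300 nM. Compound 2 holds the lower of the two numbers, but the gap to compound 1 lies within the scatter, so the two compounds read as equivalent on present evidence.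

Compound 3 `ClCc1ccccc1Cn1cnc2ncnc(Cl)c21` is the next member to be measured. Relative to compound 2 it differs as follows: hydrogen in place of chloro on an aromatic carbon. The change removes one chloro group from the six-membered aromatic ring of the fused system, at the carbon between two ring nitrogen atoms.

Among the measured compounds shown here, no measured pair here reports the effect of such a change, so no step size can be drawn from the series itself. The expectation, resting on the closeness of compound 1 and compound 2, is a step no larger than the scatter, if anything toward a somewhat higher number. Compound 3 is therefore estimated at 80000 nM in this assay, with a range from 30000 nM to 200000 nM. That estimate means an expected step of a 1.3-fold higher number from compound 2 to compound 3 (0.12 log units; within the scatter) in this assay.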

Compound 3, concentration lethal to 50% of the cells: 33900 nM
Estimate against measurement, compound 3: 2.4-fold (0.37 log units) above, within the range that was stated.
By their numbers in this assay, from the lowest: compounds 3, 2 and 1 (each within the scatter of the next, the first and the last beyond it).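

In this assay, among the compounds shown here, hydrogen in place of chloro on an aromatic carbon, between two ring nitrogen atoms, gives a 1.8-fold lower number from compound 2 to compound 3 (0.25 log units; within the scatter) and is the first step that isolates a single place on the core. Within the scatter, compound 2 and compound 3 read as equivalent, so the chloro group at this carbon is not required for a reading in this range, at least with the rest of compound 2 unchanged. Nothing at hand bears on what lies behind this reading, and the step is recorded here as an observation only.

Open, from the compounds shown here alone, is what a group other than chloro or hydrogen would give on this same carbon with the rest of compound 3 held fixed, for example a methyl group, a methoxy group or a fluoro group. Also open, going by these compounds, is whether the remaining chloro group, meta to this carbon, tolerates the same exchange, and whether a longer chain in place of the chloromethyl group changes the picture in this assay.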